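The source may report more compounds than this note shows. Statements on the series, on what has been measured and on what is new or still open speak of the compounds shown alone.

Compound 1 `CC(C)(C)OC(=O)NOc1nc(N)nc2c1ncn2[C@@H]1O[C@H](CO)[C@@H](O)[C@@]1(C)O`: in an ADME assay on PBMC cells (Homo sapiens) for cytotoxicity, read by trypan blue exclusion, with a stated time of 6 days (on this read-out lower numbers stand for higher toxicity in this test and higher numbers for lower toxicity in this test), compound 1 gives > 100000 nM, which is a limit of the test and not a number.
Compound 2 `CONc1nc(N)nc2c1ncn2[C@@H]1O[C@H](CO)[C@@H](O)[C@@]1(C)O`: in this assay compound 2 gives > 100000 nM, again a limit rather than a number.

Among the compounds with values here, compound 2 therefore stands only at a limit in this assay, and the one further value shown, that of compound 1, is a limit as well. Within the data shown here, the single measured step, a step that the two limits leave unreadable from compound 1 to compound 2, cannot be given a size because the limit of > 100000 nM in this assay, at which 2 of the 2 values shown sit, holds both values, so it tells nothing about how the cells respond to a change at that position.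

Compound 3 `C[C@@]1(O)[C@H](O)[C@@H](CO)O[C@H]1n1cnc2c(NO)nc(N)nc21` differs from compound 2 by hydrogen in place of methyl on an oxygen, a hydrogen in place of a methyl on an oxygen whose other neighbour is a nitrogen on an aromatic ring. Among the measured compounds shown here, no measured step bears on this change with a readable size, and both measured values sit at the same limit, so no step beyond the scatter is expected in this assay. The step that the limit leaves unreadable from compound 2 to compound 3 is expected to be essentially none. Compound 3 is estimated at 150000 nM, within a range from 50000 nM to 500000 nM, most likely reported again only as a limit.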

Compound 3, half-maximal cytotoxic concentration: > 100000 nM
Compound 3 was reported as a limit; the forecaster's own chance of this, stated with the estimate: 85%; the middle value is on the limit's open side.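

No new step can be read among compound 1, compound 2 and compound 3, because all three results are limits rather than numbers: the limit of > 100000 nM in this assay, at which 3 of the 3 values shown sit.

The compounds shown leave open whether any of these changes on the shared core alters the toxicity seen in this assay and at what concentration such toxicity would appear.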